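Chloro for Fluoro: Expected Cytotoxicity of Compound 4

The source may report more compounds than this note shows. Statements on the series, on what has been measured and on what is new or still open speak of the compounds shown alone.

Measured in a functional assay on MDA-MB-231 cells (Homo sapiens) for cytotoxicity, read by MTT assay, with a stated time of 72 h; on this read-out higher numbers stand for weaker inhibition and lower numbers for stronger inhibition:
Compound 1 `CN(C)CCNc1nc(-c2ccc(NC(=O)Nc3ccc(F)cc3)cc2)nc2ccsc12` gives 540 nM.
Compound 2 `CN(C)CCNc1nc(-c2ccc(NC(=O)Nc3ccc(Cl)cc3)cc2)nc2ccsc12` gives 310 nM.
Compound 3 `CCN(CC)CCCNc1nc(-c2ccc(NC(=O)Nc3ccc(F)cc3)cc2)nc2c(Cl)c(Cl)sc12` gives 1630 nM.

Compound 2 differs from compound 1 by chloro in place of fluoro on an aromatic carbon, and that change gave a 1.7-fold lower number from compound 1 to compound 2 (0.24 log units; within the scatter). Compound 3 carries a different core; the difference between the two cores is not broken down here, and in this assay compound 3 gives a number beyond the scatter from compound 1 and compound 2. Compound 4 `CCN(CC)CCCNc1nc(-c2ccc(NC(=O)Nc3ccc(Cl)cc3)cc2)nc2c(Cl)c(Cl)sc12` differs from compound 3 by chloro in place of fluoro on an aromatic carbon, the same change, at the same place, as from compound 1 to compound 2. Since that earlier step stayed within the scatter, a step of similar size is expected here: a 1.6-fold lower number from compound 3 to compound 4 (0.21 log units; within the scatter). Compound 4 is therefore estimated at 1000 nM in this assay, likely between 500 nM and 2200 nM.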

Compound 4, half-maximal inhibitory concentration: 660 nM
For compound 4 the middle estimate is 1.5-fold (0.18 log units) above the measured one; measured number inside the range.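

Chloro in place of fluoro gave a 2.5-fold lower number from compound 3 to compound 4 (0.39 log units; beyond the scatter) in this assay on the core of compound 3, a modest step. This is one pair on each core, and the two pairs also differ in their amine side chain, so it does not show that the change will carry over to further cores. Even so, the size of the step did carry over here, since the two steps cannot be told apart: the same change on two cores in this assay, a 1.7-fold lower number (0.24 log units; within the scatter) from compound 1 to compound 2 and a 2.5-fold lower number (0.39 log units; beyond the scatter) from compound 3 to compound 4, 1.4-fold (0.15 log units) apart, within the scatter of two such steps

Going by these compounds, what bromo or methoxy in place of the chloro would do remains open. So does the effect of a morpholine in place of the diethylamino group.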